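This account rests on a few compounds, and the source may have more. Where it says the series, first, only, none or still open, it means among the compounds named here.

Measured so far:
compound 1, `COc1ccc(Cn2c3c(c4ccccc4c2=O)CCOc2ccccc2-3)cc1`, 4490 nM;
compound 2, `COc1ccc(Cn2c3c(c4cc(C)ccc4c2=O)CCOc2ccccc2-3)cc1`, 9260 nM;
compound 3, `COCOc1ccccc1-c1cc2ccccc2c(=O)[nH]1`, 620 nM.

All values come from a functional assay on HL-60 cells (Homo sapiens) for cytotoxicity, read by sulforhodamine B assay; a higher number here means a weaker inhibitor, a lower number a stronger inhibitor. Compound 3 gives the lowest number of the three. How its core differs from the core of compound 1 is not broken down here. Within the core of compound 1, the change methyl in place of hydrogen on an aromatic carbon gave a step of a 2.1-fold higher number from compound 1 to compound 2 (0.31 log units; beyond the scatter). Compound 4, `COCOc1ccccc1-c1cc2cc(C)ccc2c(=O)[nH]1`, is not yet measured; it differs from compound 3 by methyl in place of hydrogen on an aromatic carbon. This is the same kind of change, not the same: the ring that receives the methyl is part of a fused system of two rings in compound 4 but of four rings in compound 2. Among the compounds with values here, for compound 4 a step of about the size of the earlier one is expected, a 2.1-fold higher number from compound 3 to compound 4 (0.32 log units; beyond the scatter), because the sole precedent is a 2.1-fold higher number from compound 1 to compound 2 (0.31 log units; beyond the scatter). Compound 4 is thus estimated at 1300 nM, within 500 nM to 3500 nM.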

Compound 4, half-maximal inhibitory concentration: 160 nM
Beside the measured number, compound 4's estimate is 8.1-fold (0.91 log units) above it, and the stated range ends above it.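

In this assay methyl in place of hydrogen on an aromatic carbon gave a 3.9-fold lower number from compound 3 to compound 4 (0.59 log units; beyond the scatter) and thus ran opposite to the earlier step, so the change did not carry over from the core of compound 1 to the core of compound 3: the same change on two cores in this assay, a 2.1-fold higher number (0.31 log units; beyond the scatter) from compound 1 to compound 2 and a 3.9-fold lower number (0.59 log units; beyond the scatter) from compound 3 to compound 4, 8.0-fold (0.90 log units) apart, beyond the scatter of two such steps.
A step measured on one of these cores is therefore a poor guide to the other for this change. This does not show which difference between the cores separates the steps, and one pair per core sets no rule for either.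

Open, going by these compounds, is whether ethyl, chlorine or an amine at the same place on the core of compound 3 would follow the methyl step. Also open, on these data alone, is which direction the methyl step would take on a third core.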